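The source may hold more compounds than are shown below. What is called first, only, known or untested is meant among the compounds shown, and "the series" means these compounds.

The series rests on two measured compounds. Compound 1 `Cc1cc(Cl)c(S(C)(=O)=O)cc1C(=O)N=C(N)N` gives 25 nM in a functional assay for inhibition of sodium/hydrogen exchanger (Oryctolagus cuniculus) (a higher number here means a weaker inhibitor, a lower number a stronger inhibitor), and compound 2 `Cc1cc(N2CCCCC2)c(S(C)(=O)=O)cc1C(=O)N=C(N)N` gives 21 nM in this assay. Compound 2 has the lowest of the two numbers, but the step of a 1.2-fold lower number from compound 1 to compound 2 (0.08 log units; within the scatter) lies within the scatter, so the two compounds cannot be ranked. Compound 3 `Cc1cc(-n2ccc(=O)cc2)c(S(C)(=O)=O)cc1C(=O)N=C(N)N` has not yet been measured. It differs from compound 2 in one place: a group of 7 heavy atoms (5 carbon, 1 nitrogen, 1 oxygen; one six-membered aromatic ring with 1 hetero atom) in place of a group of 6 heavy atoms (5 carbon, 1 nitrogen; one six-membered non-aromatic ring with 1 hetero atom), on an aromatic carbon. Among the measured compounds shown here, the only measured step that touches this position is a 1.2-fold lower number from compound 1 to compound 2 (0.08 log units; within the scatter), and it shows that a group of 6 heavy atoms in place of chloro left the number essentially unchanged. For the measured compounds named here, no step shows what the entering group does. The expected step of a 1.9-fold higher number from compound 2 to compound 3 (0.28 log units; within the scatter) is therefore small and uncertain, leaning toward a slightly higher number. Compound 3 is estimated at 40 nM in this assay, within a range of 15 nM to 120 nM.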

Compound 3, half-maximal inhibitory concentration: 75 nM
Beside the measured number, compound 3's estimate is 1.9-fold (0.27 log units) below it; the range from low to high includes it.
By their numbers in this assay, from the lowest: compounds 2 and 1 (each within the scatter of the next); then compound 3.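

Until now this position had shown no difference between chloro and piperidin-1-yl, but it does respond to the choice of group. In this assay the six-membered aromatic ring with its double bond outside the ring gives a 3.6-fold higher number from compound 2 to compound 3 (0.55 log units; beyond the scatter) and, set against chloro, a 3.0-fold higher number from compound 1 to compound 3 (0.48 log units; beyond the scatter) so compound 3 separates from both earlier compounds, each step lying beyond the scatter. Nothing available gives a reason for this shift.

What remains open is whether the step follows from the aromatic ring or from the double bond outside it, as no compound shown carries one without the other. A 4-oxopiperidin-1-yl group would separate the two, while a morpholin-4-yl or dimethylamino group would show how widely the number moves among other amines at this position.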